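Methoxymethyl for 1-Methylethenyl: One Step in Thromboxane Synthase Inhibition

A few compounds are considered here, and "the series" means these few. Any claim that something is new, unique, unknown or untested is made for them only; others in the source may bear on it.

Compound 1, `C=C(C)C(CCC/C=C(\c1ccccc1)c1cccnc1)C(=O)O`: 28 nM
Compound 2, `C/C(=C/CCCCC(=O)O)c1cccnc1`: 71 nM
Compound 3, `O=C(O)CCCCCCCCC/C=C(\c1ccccc1)c1cccnc1`: 55 nM

Of the compounds shown here, three have been measured in an assay (Equus caballus) for inhibition of Thromboxane-A synthase (Homo sapiens), using microsomes; a lower number here means a stronger inhibitor, a higher number a weaker inhibitor. Compound 1 gives 28 nM, the lowest of the three numbers. Compound 3 gives 55 nM, a value that sits within the scatter of the value for compound 1, so the two cannot be told apart. Compound 2 gives 71 nM, a higher number than compound 1 by a margin that lies beyond the scatter.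

Compound 4, `COCC(CCC/C=C(\c1ccccc1)c1cccnc1)C(=O)O`, has not yet been measured. It differs from compound 1 in one place: methoxymethyl in place of 1-methylethenyl on a saturated chain carbon bound to a carbonyl carbon and a saturated chain carbon. The group leaves and the new group enters on the saturated chain carbon bound to a carbonyl carbon and a saturated chain carbon; the rest of the shared core is unchanged. Going by the values given here, no measured pair shows this change, so no step of known size guides the expectation, and the three values seen so far lie close together.

The step is expected to be a 1.4-fold higher number from compound 1 to compound 4 (0.15 log units; within the scatter), a small move, if any, beyond the scatter. Compound 4 is accordingly estimated at 40 nM, with a range from 15 nM to 110 nM.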

Compound 4, half-maximal inhibitory concentration: 41 nM
Estimate against measurement, compound 4: 1.0-fold (0.01 log units) below; low and high end bracket the measured number.
By their numbers in this assay, from the lowest: compounds 1, 4, 3 and 2 (each within the scatter of the next, the first and the last beyond it).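

In this assay, the exchange of 1-methylethenyl for methoxymethyl on a saturated chain carbon bound to a carbonyl carbon and a saturated chain carbon gives a 1.5-fold higher number from compound 1 to compound 4 (0.17 log units; within the scatter), so compound 1 and compound 4 cannot be told apart. Going by these compounds alone, at this place, then, a group with a double bond outside aromatic rings and no hydrogen-bond acceptor and a group with no such double bond and one hydrogen-bond acceptor give values within the scatter of each other, a comparison the earlier compounds could not offer, as no two of them differ in one place. Nothing measured here speaks to why the two groups read alike.

Only these two groups are shown at this place, so it remains open whether an amine, a carboxylic acid or a longer chain on the same carbon would also stay within the scatter of compound 1. Compound 2 and compound 3 each differ from compound 1 in more than one place, so steps from them to compound 1 or compound 4 cannot be read.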